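Ortho-methyl on the anilino ring: a step between two limits

The compounds below may be only part of what the source reports. "The series", "measured", "known", "first", "only" and "open" are said of these compounds alone.

Compound 1 `Cc1cccc(Nc2nc(C)c(C(=O)/C=C/c3ccccc3Cl)s2)c1`: > 25000 nM
Compound 2 `COc1cccc(/C=C/C(=O)c2sc(Nc3ccccc3C)nc2C)c1`: > 25000 nM
Compound 3 `Cc1nc(Nc2ccccc2)sc1C(=O)/C=C/c1ccccc1Cl`: > 25000 nM

In a functional assay on NCI-H460 cells (Homo sapiens) for cytotoxicity, read by MTT assay (on this read-out lower numbers stand for stronger inhibition and higher numbers for weaker inhibition), compound 3 gives > 25000 nM, which is a limit of the assay and not a number. The same is true of compound 1 and of compound 2, so all three values sit at the limit of > 25000 nM in this assay, at which 3 of the 3 values shown sit, and none can be ordered against another. Compound 4 `Cc1ccccc1Nc1nc(C)c(C(=O)/C=C/c2ccccc2Cl)s1` differs from compound 3 by methyl in place of hydrogen on an aromatic carbon. Among the compounds with values here, the only measured step that bears on it, a step that the two limits leave unreadable from compound 1 to compound 3, is a step between two limits and gives no readable size. Compound 2 carries the same methyl next to a different arylidene, and it too sits at the limit. The data therefore offer no reason to expect compound 4 to leave the limit; the step that the limit leaves unreadable from compound 3 to compound 4 is estimated to be none beyond the scatter. For compound 4 the expected value in this assay is 40000 nM, within a range from 20000 nM to 100000 nM, most likely reported again only as a limit.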

Compound 4, half-maximal inhibitory concentration: > 25000 nM
Compound 4 was reported as a limit; the forecaster's own chance of this, stated with the estimate: 85%; the middle value is on the limit's open side.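

No step to compound 4 from compound 1, compound 2 or compound 3 can be read, since each of the four values is a limit and not a number: the limit of > 25000 nM in this assay, at which 4 of the 4 values shown sit.

The compounds shown leave open whether methyl in place of hydrogen on an aromatic carbon changes anything in this assay.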